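A Pyrrolidine Ester in Place of an Open Amino Ester

A few compounds are considered here, and "the series" means these few. Any claim that something is new, unique, unknown or untested is made for them only; others in the source may bear on it.

In a functional assay on MCF7 cells (Homo sapiens) for inhibition, read by MTT assay, with a stated time of 3 days (on this read-out higher numbers stand for weaker inhibition and lower numbers for stronger inhibition), compound 1 (`COc1cc(-c2nc3ccccc3s2)ccc1OCC(=O)NNC(=O)CCl`) gives 780 nM and compound 2 (`COc1cc(-c2nc3ccccc3s2)ccc1OCC(=O)NNC(O)CN(C)CC(=O)O`) gives 1960 nM while compound 3 (`CCOC(=O)CN(C)CC(=O)NNC(=O)COc1ccc(-c2nc3ccccc3s2)cc1OC`) gives 1980 nM on the same read-out. Compound 3 thus stands level with compound 2 (a 1.0-fold higher number from compound 2 to compound 3 (0.00 log units; within the scatter)) and on the weaker side of compound 1.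

The next case is compound 4 (`CCOC(=O)[C@@H]1CCCN1CC(=O)NNC(=O)COc1ccc(-c2nc3ccccc3s2)cc1OC`), which carries 2-(ethoxycarbonyl)pyrrolidin-1-yl in place of ((ethoxycarbonyl)methyl)(methyl)amino on a saturated chain carbon bound to a carbonyl carbon. The entering group brings one five-membered non-aromatic ring and 1 defined stereocentre.

Among the compounds with values here, no measured step makes this exact change. The nearest evidence is the swap of chloro for the open amino ester group at that same carbon (a 2.5-fold higher number from compound 1 to compound 3 (0.40 log units; beyond the scatter)), a modest step. The other change away from the chloro side chain was of the same size (a 2.5-fold higher number from compound 1 to compound 2 (0.40 log units; beyond the scatter)), while the two amino side chains could not be told apart. Nothing measured here tests the ring, so no step beyond the scatter is expected in this assay for this swap. The estimated change is small (a 1.2-fold lower number from compound 3 to compound 4 (0.09 log units; within the scatter)). Compound 4 is expected at 1600 nM within an estimated range from 650 nM to 4000 nM on this reasoning.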

Compound 4, half-maximal inhibitory concentration: 770 nM
Estimate against measurement, compound 4: 2.1-fold (0.32 log units) above; the range from low to high includes it.
By their numbers in this assay, from the lowest: compounds 4 and 1 (each within the scatter of the next); then compounds 2 and 3 (each within the scatter of the next).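

In this assay, the change on the saturated chain carbon bound to a carbonyl carbon is not silent: 2-(ethoxycarbonyl)pyrrolidin-1-yl in place of ((ethoxycarbonyl)methyl)(methyl)amino gives a 2.6-fold lower number from compound 3 to compound 4 (0.41 log units; beyond the scatter), the first sign that the amino ester side chain can be varied with a step beyond the scatter, since the two earlier amino side chains could not be told apart. It also shows that an amino ester at this carbon need not fall on the weaker side of the chloro side chain: the open amino ester did, whereas the pyrrolidine ester gives a 1.0-fold lower number from compound 1 to compound 4 (0.01 log units; within the scatter), so that chloro and the pyrrolidine ester cannot be told apart on this read-out. Nothing available explains why the ring form differs from the open form.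

The compounds shown leave open whether the gain belongs to the five-membered ring itself, to its defined stereocentre or to both, which the opposite stereoisomer or a plain pyrrolidin-1-yl group lacking the ester would help to separate. They also leave open how a piperidine ring, or a carboxylic acid in place of the ethyl ester on the pyrrolidine, would behave at this carbon.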